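The source may hold more compounds than are shown below. What is called first, only, known or untested is meant among the compounds shown, and "the series" means these compounds.

Compound 1 `Cc1ccc(C(=O)OC2CCN(C)CC2)cc1` gives 1.17 in a functional assay on the whole organism with Mus musculus as the target (a lower number here means a less potent compound, a higher number a more potent compound, by a factor of ten per unit of this negative logarithm), the lowest of the three numbers measured, though within the scatter of both others. Compound 2 `Cc1ccc(C(=O)OC2CCN(C)CC2)cc1F` gives 1.32 in this assay, and compound 3 `CN1CCC(OC(=O)c2ccccc2Cc2ccccc2)CC1` gives 1.28 in this assay. Within the data shown here, the only measured step between neighbouring structures is a number 0.15 log units higher from compound 1 to compound 2 (within the scatter), a change at an aromatic carbon that stayed within the scatter. Compound 4 `CN1CCC(OC(=O)c2ccc(C#N)cc2)CC1` is not yet measured and differs from compound 1 by cyano in place of methyl on an aromatic carbon. Among the measured compounds shown here, no measured step exchanges one substituent for another on that ring, so the sole guide is that small aromatic change, which did not move the number. A step beyond the scatter is therefore not expected. Compound 4 is estimated at 1.2, between 0.7 and 1.7, which is expected to mean a number 0.03 log units higher from compound 1 to compound 4 (within the scatter).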

Compound 4, logarithm of the reciprocal of the active concentration, log(1/C): 1.65
The estimate for compound 4 lay 0.45 log units below the measured number, and the stated range covers the measured number.
By their numbers in this assay, from the lowest: compounds 1, 3 and 2 (each within the scatter of the next); then compound 4.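

In this assay, among these compounds, the exchange of methyl for cyano, on an aromatic carbon para to a large group, gives a number 0.48 log units higher from compound 1 to compound 4 (beyond the scatter) and is the first step here to pass the scatter. The earlier fluoro step stayed within it, whereas this step shows that the number does respond, modestly, to the group at this position. Nothing at hand explains the difference. Going by these compounds, it remains open whether an amine, a carboxylic acid or a methoxy group at this position would move the number as far. On these data alone, whether cyano would give a similar step with fluoro also on the ring is equally open.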